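A few compounds are considered here, and "the series" means these few. Any claim that something is new, unique, unknown or untested is made for them only; others in the source may bear on it.

Measured so far in a functional assay on DLD-1 cells (Homo sapiens) for antiproliferative activity, read by CellTiter-Glo, with a stated time of 72 h; a lower number here means a stronger inhibitor, a higher number a weaker inhibitor:
compound 1, `COc1ccc(-c2cccc(S(=O)(=O)N3CCC(N4CCC(C)CC4)CC3)c2)cc1`: 23 nM
compound 2, `COC(=O)c1ccc(S(=O)(=O)N2CCC(N3CCC(C)CC3)CC2)cc1`: > 5000 nM
compound 3, `Cc1cc(C)c(S(=O)(=O)N2CCC(c3ccccc3)CC2)c(C)c1`: > 5000 nM

Among the measured compounds shown here, compound 1 gives 23 nM in this assay, and this is the only actual number among the three results. For compound 2 the assay reports only a limit, > 5000 nM. For compound 3 it likewise reports only a limit, > 5000 nM. The other two results are therefore (the limit of > 5000 nM in this assay, at which 2 of the 3 values shown sit). For the measured compounds named here, no two of the measured compounds differ in just one place, so no single step between them can be sized.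

Compound 4, `CC1CCN(C2CCN(S(=O)(=O)c3cccc(N)c3)CC2)CC1`, is the compound still to be measured. It differs from compound 1 in one place: amino in place of 4-methoxyphenyl on an aromatic carbon. A whole 4-methoxyphenyl ring leaves and a single amino takes its place on the shared core. Nothing measured bears directly on this change, but removing so much of the molecule is expected to weaken inhibition well beyond the usual scatter. The expected step is a 130-fold higher number from compound 1 to compound 4 (2.12 log units; beyond the scatter). Compound 4 is expected to give 3000 nM, between 500 nM and 20000 nM, with a real chance that only a limit is reported.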

Compound 4, half-maximal inhibitory concentration: 3400 nM
Compound 4: middle estimate off by 1.1-fold (0.05 log units), on the low side; the range from low to high includes it.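

In this assay, amino in place of 4-methoxyphenyl gives a 150-fold higher number from compound 1 to compound 4 (2.17 log units; beyond the scatter), the first step among these compounds that can be sized. It shows that inhibition is highly sensitive to the group on this aromatic carbon, and that much of the strength of compound 1 is lost when the 4-methoxyphenyl group leaves. Even so, compound 4 gives 3400 nM, a real number. Compound 2 and compound 3 remain the only results that sit at the limit: the limit of > 5000 nM in this assay, at which 2 of the 4 values shown sit.

This single step cannot separate the part played by the aromatic ring from that of its methoxy group, or show whether amino itself contributes anything. An unsubstituted phenyl ring or a 4-hydroxyphenyl group on the same carbon would help to separate these effects.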